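The source may report more compounds than this note shows. Statements on the series, on what has been measured and on what is new or still open speak of the compounds shown alone.

Measured compounds in a functional assay on HL-60 cells (Homo sapiens) for cytotoxicity, read by MTT assay, with a stated time of 72 h; on this read-out lower numbers stand for stronger inhibition and higher numbers for weaker inhibition:
compound 1 `COc1ccc(-c2nnc3nnc(N4CCCCC4)n3n2)cc1` gives 12900 nM
compound 2 `Clc1ccccc1-c1nnc2nnc(N3CCCC3)nn12` gives 2660 nM
compound 3 `O=[N+]([O-])c1ccc(-c2nnc3nnc(N4CCCCC4)n3n2)cc1` gives 610 nM

Compound 2 stands second highest of the three. Its nearest neighbour is compound 3, whose number is lower and beyond the scatter, and its furthest is compound 1, whose number is higher and beyond the scatter.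

Compound 4 `CC(C)c1nnc2nnc(N3CCCC3)nn12` differs from compound 2 by isopropyl in place of 2-chlorophenyl on an aromatic carbon. Among the measured compounds shown here, the only measured step, a 21-fold lower number from compound 1 to compound 3 (1.33 log units; beyond the scatter), concerns a substituent on the aromatic ring that stays in place, not the removal of that ring, so nothing measured bears directly on this change. Without a comparable step, compound 4 is expected to give a modestly higher number than compound 2, a 3.0-fold higher number from compound 2 to compound 4 (0.48 log units; beyond the scatter), and its estimated value is 8000 nM, within a range of 2000 nM to 32000 nM.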

Compound 4, half-maximal inhibitory concentration: 71200 nM
Estimate against measurement, compound 4: 8.9-fold (0.95 log units) below; the whole stated range lies below it.
By their numbers in this assay, from the lowest: compound 3; then compound 2; then compound 1; then compound 4.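

In this assay the group on the aromatic carbon between two ring nitrogen atoms matters greatly: a 27-fold higher number from compound 2 to compound 4 (1.43 log units; beyond the scatter) follows when isopropyl replaces 2-chlorophenyl. The earlier step changed a substituent on an aromatic ring that stayed in place, whereas this change removes the ring itself, and the loss is large. Nothing available explains this loss.

From the compounds shown here alone, it remains open whether the ring alone accounts for the difference, or whether the chlorine also contributes. An unsubstituted phenyl or a cyclohexyl at this place would separate these possibilities.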